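A few compounds are considered here, and "the series" means these few. Any claim that something is new, unique, unknown or untested is made for them only; others in the source may bear on it.

Series notes. Compound 1 `O=S(=O)(c1ccc(F)cc1)c1cc(F)c(O)c2ncccc12` carries a 4-fluorophenyl group on the sulfonyl sulfur of the shared core. In an assay on cells for inhibition of Catechol O-methyltransferase (Rattus norvegicus), with a stated time of 1 h, in the presence of a further agent that is not named here (a lower number here means a stronger inhibitor, a higher number a weaker inhibitor), compound 1 gives < 1 nM, which is a limit of the assay rather than a number. Compound 2 `O=S(=O)(c1cc(F)c(O)c2ncccc12)C1CCCC1` has a cyclopentyl in place of that 4-fluorophenyl on the sulfonyl sulfur. In this assay compound 2 gives < 1 nM, again a limit of the assay. The step that the two limits leave unreadable from compound 1 to compound 2 therefore cannot be read as a size. Where compound 2 stands is fixed only by that limit, and the one further value shown is a limit as well, both sitting at the limit of < 1 nM in this assay, at which 2 of the 2 values shown sit. Compound 3 `O=S(=O)(c1cc(Cl)c(O)c2ncccc12)C1CCCC1` is the next member: chloro in place of fluoro on an aromatic carbon. No measured step bears directly on this change: the single step shown concerns the group on the sulfonyl sulfur, and its size is unreadable. Compound 2 sits at the limit of < 1 nM in this assay, at which 2 of the 2 values shown sit. Compound 3 is expected to stay near that limit, the step that the limit leaves unreadable from compound 2 to compound 3 being estimated as small. For compound 3 in this assay the estimate is 0.7 nM, within 0.2 nM to 3 nM.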

Compound 3, half-maximal inhibitory concentration: < 1 nM
Compound 3: a limit, no number; the forecaster's own chance of this, stated with the estimate: 60%; the middle value is on the limit's open side.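

No new step can be read: the step from compound 2 to compound 3 has no readable size, because compound 1, compound 2 and compound 3 all sit at one limit of the assay: the limit of < 1 nM in this assay, at which 3 of the 3 values shown sit. Going by these compounds, how far these three compounds differ in this assay stays open, as does whether chloro in place of fluoro, or cyclopentyl in place of 4-fluorophenyl, changes inhibition at all.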